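The compounds below may be only part of what the source reports. "The series", "measured", "known", "first", "only" and "open" are said of these compounds alone.

In a functional assay on HepG2 cells (Homo sapiens) for inhibition, read by MTT assay, with a stated time of 24 h (a higher number here means a weaker inhibitor, a lower number a stronger inhibitor), compound 2 `CC1(C)[C@H]2CC[C@]1(C)N(Cc1cn(-c3ccccc3Br)nn1)C(=O)C2` gives 150 nM and compound 1 `CC1(C)[C@H]2CC[C@]1(C)N(Cc1cn(-c3cccc(F)c3)nn1)C(=O)C2` gives 80 nM, so the two numbers lie within the scatter of each other. Compound 3 `CC1(C)[C@H]2CC[C@]1(C)N(Cc1cn(-c3ccc(C#N)cc3)nn1)C(=O)C2` carries 4-cyanophenyl in place of 2-bromophenyl on an aromatic nitrogen. For the measured compounds named here, the only measured step that bears on this change is a 1.9-fold higher number from compound 1 to compound 2 (0.27 log units; within the scatter), which also exchanges the group on that nitrogen. Going by the values given here, with only this step to go on, no change beyond the scatter is expected in this assay. The expected size is a 1.3-fold lower number from compound 2 to compound 3 (0.10 log units; within the scatter). Compound 3 is estimated at 120 nM, with an expected range of 40 nM to 350 nM.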

Compound 3, half-maximal inhibitory concentration: 50 nM
The estimate for compound 3 lay 2.4-fold (0.38 log units) above the measured number, and the stated range covers the measured number.
By their numbers in this assay, from the lowest: compounds 3, 1 and 2 (each within the scatter of the next, the first and the last beyond it).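

In this assay, for the compounds shown here, 4-cyanophenyl in place of 2-bromophenyl on the aromatic nitrogen gives a 3.0-fold lower number from compound 2 to compound 3 (0.48 log units; beyond the scatter), the first step beyond the scatter. Against 3-fluorophenyl, 4-cyanophenyl gives a 1.6-fold lower number from compound 1 to compound 3 (0.20 log units; within the scatter), so these two groups are not separated at this position. Nothing measured here explains the step from 2-bromophenyl. Because the names 2-bromophenyl and 4-cyanophenyl differ in both substituent and number, the contribution of each remains unresolved. Also open, on these data alone, is how a phenyl ring carrying an amine or a carboxylic acid would behave at this nitrogen.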